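Alkoxy chain length and electroshock potency in one series

The source may hold more compounds than are shown below. What is called first, only, known or untested is meant among the compounds shown, and "the series" means these compounds.

Four compounds share a core and differ only in the length of an alkoxy chain. Compound 1 `CCOc1ccc(-n2cnnc2CC)cc1` bears the shortest chain; compound 2 `CCCCCCOc1ccc(-n2cnnc2CC)cc1`, compound 3 `CCCCCCCCOc1ccc(-n2cnnc2CC)cc1` and the not yet tested compound 4 `CCCCCCCCCCCCOc1ccc(-n2cnnc2CC)cc1` carry longer ones. In a functional assay on the whole organism (strain C57B/6) with Mus musculus as the target, in the maximal electroshock model (on this read-out higher numbers stand for an effect only at larger amounts of compound and lower numbers for an effect already at smaller amounts), compound 1 gives only a limit of the assay, > 100 mg/kg. Compound 2 gives 13.2 mg/kg in this assay, and compound 3 gives 8.8 mg/kg.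

The step of an at least 7.5-fold lower number from compound 1 to compound 2 (0.87 log units; beyond the scatter) goes with the change (butyl in place of hydrogen on a saturated chain carbon, two bonds along the chain from an oxygen on an aromatic ring). The step of an at least 11-fold lower number from compound 1 to compound 3 (1.05 log units; beyond the scatter) goes with hexyl in place of hydrogen on a saturated chain carbon, two bonds along the chain from an oxygen on an aromatic ring, which is also how the core of compound 3 differs from the core of compound 1. Between compound 2 and compound 3 the step is a 1.5-fold lower number from compound 2 to compound 3 (0.18 log units; within the scatter).

Compound 4 arises from compound 3 by butyl in place of hydrogen on a saturated chain carbon, eight bonds along the chain from an oxygen on an aromatic ring. This is the same kind of change as butyl in place of hydrogen on a saturated chain carbon, two bonds along the chain from an oxygen on an aromatic ring, but not the same: in the earlier pair the butyl enters two bonds along the chain from an oxygen on an aromatic ring, here eight bonds along the chain from an oxygen on an aromatic ring. The earlier instance gave an at least 7.5-fold lower number from compound 1 to compound 2 (0.87 log units; beyond the scatter). From compound 3 to compound 4 a step of only a 1.1-fold higher number from compound 3 to compound 4 (0.06 log units; within the scatter) is expected, much smaller than that one, because the step of a 1.5-fold lower number from compound 2 to compound 3 (0.18 log units; within the scatter) shows the gain from further chain lengthening already flattening. Compound 4 is therefore expected to give about 10 mg/kg in this assay, with a likely range from 5 mg/kg to 30 mg/kg.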

Compound 4, dose for half-maximal effect: > 100 mg/kg
Compound 4: a limit, no number (the forecaster's own chance of this, stated with the estimate: 15%); at least 10-fold (1.00 log units) between middle value and limit.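

In this assay, butyl in place of hydrogen on a saturated chain carbon, eight bonds along the chain from an oxygen on an aromatic ring, goes with an at least 11-fold higher number from compound 3 to compound 4 (1.05 log units; beyond the scatter), so the change does not carry over from the core of compound 1 to the core of compound 3 and instead runs the opposite way: the same change on two cores in this assay, an at least 7.5-fold lower number (0.87 log units; beyond the scatter) from compound 1 to compound 2 and an at least 11-fold higher number (1.05 log units; beyond the scatter) from compound 3 to compound 4, at least 86-fold (1.93 log units) apart, beyond the scatter of two such steps

The longer insertion behaves alike, going with an at least 7.5-fold higher number from compound 2 to compound 4 (0.87 log units; beyond the scatter), which again reverses the direction seen on the shorter chain: the same change on two cores in this assay, an at least 11-fold lower number (1.05 log units; beyond the scatter) from compound 1 to compound 3 and an at least 7.5-fold higher number (0.87 log units; beyond the scatter) from compound 2 to compound 4, at least 86-fold (1.93 log units) apart, beyond the scatter of two such steps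

Compound 1 and compound 4 each give a limit and not a number, so these steps bound the reversal without fixing its size, and they give no reason for it: the limit of > 100 mg/kg in this assay, at which 2 of the 4 values shown sit.

The compounds shown leave open where along the chain the turn occurs, since a decyl chain on the shared core could sit near compound 2 and compound 3 or at the limit of compound 4. Also open, going by these compounds, is whether a hydroxyl or an amine at the far end of the longest chain would change the result in this model.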